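Propanoyl to isopropylcarbonyl: from compound 3 to compound 4

A few compounds are considered here, and "the series" means these few. Any claim that something is new, unique, unknown or untested is made for them only; others in the source may bear on it.

- compound 1 `CCCC(=O)c1ccc(OCCCCOc2cc(C(=O)O)ccc2OC)c(C)c1O`: 78%
- compound 2 `Cc1c(OCCCCOc2ccc(F)c(C(=O)O)c2)ccc(C(=O)CC(C)(C)C)c1O`: 83%
- compound 3 `CCC(=O)c1ccc(OCCCCOc2ccc(F)c(C(=O)O)c2)c(C)c1O`: 96%

In an ADME assay on a cell-free system (plasma, Rattus norvegicus) for metabolic stability, read by LC-MS, with a stated time of 60 min, tested at 100 uM (a lower number here means that less of the compound is left, a higher number that more of the compound is left), compound 3, at 96%, holds the highest of the three numbers. Compound 2 and compound 1 both lie lower by more than the scatter.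

The next structure is compound 4 `Cc1c(OCCCCOc2ccc(F)c(C(=O)O)c2)ccc(C(=O)C(C)C)c1O`. The change is methyl in place of hydrogen on a saturated chain carbon bound to a carbonyl carbon and a saturated chain carbon, so that ethyl becomes isopropyl.

Going by the values given here, only one measured step bears on this change, and it changes a group at a saturated chain carbon bound to a carbonyl carbon. That modest step, with methyl in place of tert-butyl, is a number 13 percentage points higher from compound 2 to compound 3 (beyond the scatter). Read backwards, it links the larger group of compound 2 to the lower number, but a single step sets no trend. The change to compound 4 adds only one methyl, so a small fall is expected, perhaps none beyond the scatter in this assay. The expected step is a number 6 percentage points lower from compound 3 to compound 4 (within the scatter). Compound 4 is estimated at 90%, with an expected range of 80% to 100%.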

Compound 4, percent of the compound remaining: 83%
Compound 4: middle estimate off by 7 percentage points, on the high side; measured number inside the range.
By their numbers in this assay, from the lowest: compounds 1, 2 and 4 (each within the scatter of the next); then compound 3.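

In this assay, one methyl in place of hydrogen on a saturated chain carbon bound to a carbonyl carbon and a saturated chain carbon produces a step beyond the scatter (a number 13 percentage points lower from compound 3 to compound 4 (beyond the scatter)), so this position responds to a change of a single carbon. That step has the same printed size as the one between the tert-butyl and methyl pair (a number 13 percentage points higher from compound 2 to compound 3 (beyond the scatter)), while isopropyl in place of neopentyl on a carbonyl carbon separates nothing (no change at the digits printed from compound 2 to compound 4 (within the scatter)); among these three compounds, only compound 3 stands apart, and the numbers show no graded order across the three groups. Nothing here gives a reason for either step.

Still open, going by these compounds, is how this position behaves with a group such as cyclopropyl, a straight propyl chain or a plain methyl on the carbonyl carbon, with the rest of compound 3 unchanged. Also open, on these data alone, is whether the fall from compound 3 to compound 4 would recur with another substituent in place of the fluorine on the shared core.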